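The source may hold more compounds than are shown below. What is called first, only, known or untested is meant among the compounds shown, and "the series" means these compounds.

For the measured compounds named here, compound 1 `CNc1nc(-n2cc(-c3ccccn3)nn2)nc2c1ncn2[C@@H]1O[C@H](CO)[C@@H](O)[C@H]1O` is one of two compounds measured in an assay on CHO cells for displacement of a labelled ligand from adenosine receptor A1 (Homo sapiens); on this read-out higher numbers stand for weaker inhibition and lower numbers for stronger inhibition. Compound 1 gives 1970 nM, the higher of the two numbers, so it is the weaker binder. Compound 2 `CNc1nc(-c2cn(Cc3cccc(Cl)c3)nn2)nc2c1ncn2[C@@H]1O[C@H](CO)[C@@H](O)[C@H]1O` gives 956 nM in this assay. Compound 3 `CNc1nc(-n2cc(CC3CCCC3)nn2)nc2c1ncn2[C@@H]1O[C@H](CO)[C@@H](O)[C@H]1O` is the compound still to be measured; it differs from compound 1 in one place: cyclopentylmethyl in place of pyridin-2-yl on an aromatic carbon. Going by the values given here, with no comparable step among the measured compounds to lean on, the change is expected to move the number little, if at all, beyond the scatter, estimated as a 1.5-fold lower number from compound 1 to compound 3 (0.18 log units; within the scatter). The estimate for compound 3 in this assay is 1300 nM, within the range 300 nM to 5500 nM.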

Compound 3, inhibition constant: 335 nM
Compound 3: the middle estimate sits 3.9-fold (0.59 log units) above what was measured; low and high end bracket the measured number.
By their numbers in this assay, from the lowest: compound 3; then compound 2; then compound 1.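

At this aromatic carbon of the five-membered ring, the choice of group clearly matters in this assay: cyclopentylmethyl in place of pyridin-2-yl gives a 5.9-fold lower number from compound 1 to compound 3 (0.77 log units; beyond the scatter) and stronger inhibition. Both groups have the same count of heavy atoms, so the number can shift substantially without that count changing; the entering group differs in having no nitrogen and a non-aromatic ring. Nothing available explains this shift.

A plain phenyl group at this position would help separate the loss of the ring nitrogen from the loss of the aromatic ring. A straight pentyl chain would show whether the cyclopentane ring itself is needed.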